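Cytotoxicity Limits Across a Shared Core

The source may hold more compounds than are shown below. What is called first, only, known or untested is meant among the compounds shown, and "the series" means these compounds.

compound 1 `CC1CCCCN1c1nc(Cc2c(F)cccc2F)cc(=O)[nH]1`: > 78000 nM
compound 2 `CCN(C)c1nc(Cc2c(F)cccc2F)c(C)c(=O)[nH]1`: > 85000 nM

In an ADME assay on MT4 cells (Homo sapiens) for cytotoxicity, read by MTT assay, with a stated time of 4 days (a lower number here means that less compound is tolerated, a higher number that more compound is tolerated), compound 1 gives > 78000 nM, a limit of the assay rather than a number. Compound 2 gives > 85000 nM in this assay, again a limit and not a number. Compound 2 stands at the limit of > 85000 nM in this assay, at which 1 of the 2 values shown sits. Compound 1 sits at the limit of > 78000 nM in this assay, at which 1 of the 2 values shown sits. Compound 3 `Cc1c(Cc2c(F)cccc2F)nc(N2CCCC(C)C2)[nH]c1=O` has not been measured; it carries 3-methylpiperidin-1-yl in place of ethyl(methyl)amino on an aromatic carbon. Among the compounds with values here, both measured values are limits, so no step between them can be sized. The step that the limit leaves unreadable from compound 2 to compound 3 is expected to be none beyond the scatter. Compound 3 is therefore expected to give 100000 nM, in the range 50000 nM to 300000 nM, most likely again reported as a limit.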

Compound 3, half-maximal cytotoxic concentration: > 75000 nM
Compound 3: no number, only a limit; the forecaster's own chance of this, stated with the estimate: 85%; the middle value is on the limit's open side.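

Within the data shown here, compound 2 and compound 3 are both reported only as limits in this assay, so no step between them can be read. The compounds shown leave open what concentration of any of them would reach the half-maximal cytotoxic effect.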